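The source may report more compounds than this note shows. Statements on the series, on what has been measured and on what is new or still open speak of the compounds shown alone.

Compound 2 `C=C(CC)C(=O)c1ccc(OCC(=O)NCC(=O)O)c(Cl)c1Cl` carries a carboxymethyl group on the amide-type nitrogen of the shared core. In a functional assay on CLL cells (Homo sapiens) for cytotoxicity, read by MTT assay, with a stated time of 48 h (a higher number here means that more compound is needed for the effect, a lower number that less compound is needed), compound 2 reaches only the limit of the assay, > 25000 nM, so no number is known for it. Among the three compounds measured, one sits at that limit (the limit of > 25000 nM in this assay, at which 1 of the 3 values shown sits). Compound 1 `C=C(CC)C(=O)c1ccc(OCC(=O)Nc2ccc(C(=O)OC)cc2)c(Cl)c1Cl` gives 4100 nM in this assay, and compound 3 `C=C(CC)C(=O)c1ccc(OCC(=O)NCC2CCC(C(=O)O)CC2)c(Cl)c1Cl` gives 8000 nM. Compound 4 `C=C(CC)C(=O)c1ccc(OCC(=O)NC(CS)C(=O)OCC)c(Cl)c1Cl` differs from compound 2 in one place: 1-(ethoxycarbonyl)-2-sulfanylethyl in place of carboxymethyl on an amide-type nitrogen. Within the data shown here, the only measured step that starts from compound 2 is an at least 3.1-fold lower number from compound 2 to compound 3 (0.49 log units; beyond the scatter), in which the carboxy on the saturated chain carbon gives way to 4-carboxycyclohexyl and the number falls. Among the measured compounds shown here, the change to compound 4 also takes away the carboxymethyl group, but no measured step shows what the entering 1-(ethoxycarbonyl)-2-sulfanylethyl group does on its own. A modest lowering of the number is therefore expected, an at least 3.1-fold lower number from compound 2 to compound 4 (0.49 log units; beyond the scatter), with the size left open by the limit. Compound 4 is estimated at 8000 nM, within a range from 2500 nM to 25000 nM.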

Compound 4, half-maximal effective concentration: 4800 nM
The estimate for compound 4 lay 1.7-fold (0.22 log units) above the measured number; the measured number falls inside the stated range.
By their numbers in this assay, from the lowest: compounds 1, 4 and 3 (each within the scatter of the next). At a limit, above all of these: compound 2.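

In this assay, putting 1-(ethoxycarbonyl)-2-sulfanylethyl in place of carboxymethyl on the amide-type nitrogen gives an at least 5.2-fold lower number from compound 2 to compound 4 (0.71 log units; beyond the scatter). This is a second group at this position that leaves the limit of compound 2 behind, and unlike the 4-carboxycyclohexyl group of compound 3 it has no ring, so among the compounds shown a ring is not required for the number to fall. The true size of the step stays unknown because compound 2 has no exact number, only a limit: the limit of > 25000 nM in this assay, at which 1 of the 4 values shown sits.

Which part of the entering group goes with the lower number stays open, since its sulfanyl and ethoxycarbonyl parts arrive together. A 1-carboxy-2-sulfanylethyl group, or a propyl chain carrying only the ethyl ester, would separate those two parts.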